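Ether variation on the shared core of compound 1

The source may report more compounds than this note shows. Statements on the series, on what has been measured and on what is new or still open speak of the compounds shown alone.

Measured so far:
compound 1 `CC(C)COc1ccc2c(Cl)ccnc2c1` — 3190 nM
compound 2 `CN(C)CCCNc1ccnc2cc(OCc3ccc(F)cc3)ccc12` — 1280 nM
compound 3 `CC(C)Oc1ccc2c(Cl)ccnc2c1` — 3060 nM

In a functional assay on SK-OV-3 cells (Homo sapiens) for cytotoxicity, read by MTT assay, with a stated time of 48 h (a higher number here means a weaker inhibitor, a lower number a stronger inhibitor), compound 1 gives the highest of the three numbers; compound 3 sits within the scatter of it, and compound 2 gives a number beyond the scatter below it. Among the compounds with values here, the only single-point step, a 1.0-fold lower number from compound 1 to compound 3 (0.02 log units; within the scatter), shows that swapping one small alkyl for another leaves the read-out unchanged. Compound 4 `Clc1ccnc2cc(OCc3ccccc3)ccc12` differs from compound 1 as follows: phenyl in place of isopropyl on a saturated chain carbon bound to an oxygen on an aromatic ring. Within the data shown here, no measured step isolates an aryl group entering at this place; compound 2 carries a related ether but also a different group elsewhere, so its value cannot be attributed. A modest step toward a lower number is expected, a 1.5-fold lower number from compound 1 to compound 4 (0.16 log units; within the scatter), with a wide range. Compound 4 is estimated at 2200 nM, between 900 nM and 5000 nM.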

Compound 4, half-maximal inhibitory concentration: 5170 nM
For compound 4 the middle estimate is 2.4-fold (0.37 log units) below the measured one; the whole stated range lies below it.
By their numbers in this assay, from the lowest: compound 2; then compounds 3, 1 and 4 (each within the scatter of the next).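

In this assay, phenyl in place of isopropyl on a saturated chain carbon bound to an oxygen on an aromatic ring gives a 1.6-fold higher number from compound 1 to compound 4 (0.21 log units; within the scatter). This extends what a 1.0-fold lower number from compound 1 to compound 3 (0.02 log units; within the scatter) showed for alkyl groups: a six-membered aromatic ring at this place also gives a step within the scatter. Nothing available explains this result.

Still open, from the compounds shown here alone, is how an amine, a carboxylic acid or a longer chain at this place would read. Also open, going by these compounds, is whether a fluorine on the phenyl changes the number with the rest of compound 4 held fixed.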